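A few compounds are considered here, and "the series" means these few. Any claim that something is new, unique, unknown or untested is made for them only; others in the source may bear on it.

Compound 1 `COc1ccc(C2=C(c3cc(OC)c(OC)c(OC)c3)C(=O)CC2O[SiH2]C(C)(C)C)cc1`: > 100 ug/mL (a limit)
Compound 2 `COc1ccc(OC)c(C2=C(c3cc(OC)c(OC)c(OC)c3)C(=O)CC2O[SiH2]C(C)(C)C)c1`: 17 ug/mL
Compound 3 `COC(=O)c1cc(C2=C(c3cc(OC)c(OC)c(OC)c3)C(=O)CC2O[SiH2]C(C)(C)C)ccc1OC`: > 100 ug/mL (a limit)

In an ADME assay on PA-1 cells (Homo sapiens) for cytotoxicity, read by MTT assay, with a stated time of 72 h (on this read-out lower numbers stand for stronger inhibition and higher numbers for weaker inhibition), compound 3 stands at > 100 ug/mL, a limit and not a number. This is the limit of > 100 ug/mL in this assay, at which 2 of the 3 values shown sit.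

Compound 4 `COc1ccc(C2=C(c3cc(OC)c(OC)c(OC)c3)C(=O)CC2O[SiH2]C(C)(C)C)cc1OC` differs from it in one place: methoxy in place of methoxycarbonyl on an aromatic carbon. In words, this is methoxy in place of methoxycarbonyl on an aromatic carbon, giving 3,4-dimethoxyphenyl.

For the measured compounds named here, two measured steps bear on this change: an at least 5.8-fold higher number from compound 2 to compound 3 (0.76 log units; beyond the scatter) and an at least 5.8-fold lower number from compound 1 to compound 2 (0.76 log units; beyond the scatter). The third, a step that the two limits leave unreadable from compound 1 to compound 3, gives no guide.

Going by the values given here, with an at least 5.8-fold higher number from compound 2 to compound 3 (0.76 log units; beyond the scatter) as the closest precedent, a modest move to a lower number is expected, although a second limit remains possible. The expected change is an at least 2.0-fold lower number from compound 3 to compound 4 (0.30 log units; that floor lies within the scatter).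

For compound 4, the estimate is 50 ug/mL, with an expected range of 12 ug/mL to 150 ug/mL.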

Compound 4, half-maximal inhibitory concentration: > 100 ug/mL
Compound 4 gave a limit, no number; the forecaster's own chance of this, stated with the estimate: 45%; middle value at least 2.0-fold (0.30 log units) away from the limit.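

Putting methoxy in place of methoxycarbonyl, at this place ortho to a methoxy group, still gives no readable number in this assay: compound 4 gives > 100 ug/mL, which is a limit. For the compounds shown here, the one readable step is an at least 5.8-fold higher number from compound 2 to compound 4 (0.76 log units; beyond the scatter), which shows that 3,4-dimethoxyphenyl does not match 2,5-dimethoxyphenyl here, while the steps to compound 4 from compound 1 and compound 3 cannot be read. Only compound 2 now carries a number, and the others share one limit: the limit of > 100 ug/mL in this assay, at which 3 of the 4 values shown sit.

On these data alone, whether an amine or a carboxylic acid at this place would give a readable number remains open.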